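From carboxy to ethoxycarbonyl on a shared core

This account rests on a few compounds, and the source may have more. Where it says the series, first, only, none or still open, it means among the compounds named here.

Measured so far:
- compound 1 `COCCn1cc(C(=O)C(=O)Nc2ccc(OCC(=O)O)nc2)c2ccccc21` gives > 10000 nM
- compound 2 `COc1nc(NC(=O)C(=O)c2cn(C(C)C)c3ccccc23)ns1` gives > 10000 nM

In a functional assay on FaDu cells (Homo sapiens) for cytotoxicity, read by MTT assay, with a stated time of 72 h (on this read-out lower numbers stand for higher toxicity in this test and higher numbers for lower toxicity in this test), compound 1 gives > 10000 nM as a limit, not a number. Compound 2 gives > 10000 nM in this assay and this too is only a limit. The whole record so far is the limit of > 10000 nM in this assay, at which 2 of the 2 values shown sit, and it offers no exact value to start from.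

Compound 3 `CCOC(=O)COc1ccc(NC(=O)C(=O)c2cn(CCOC)c3ccccc23)cn1` has ethyl in place of hydrogen on an oxygen next to a carbonyl group, so carboxy becomes ethoxycarbonyl ethyl in place of hydrogen on an oxygen next to a carbonyl group in the structure of compound 1. Going by the values given here, no measured pair shows what this change does. Starting from the limit of compound 1, any exact number that appears could only point toward higher toxicity. The expected result in this assay is a modest move in that direction, shown as an at least 1.6-fold lower number from compound 1 to compound 3 (0.22 log units; that floor lies within the scatter) and a repeat of the limit remains quite possible. For compound 3 the estimated value is 6000 nM with an expected range from 1000 nM to 30000 nM for the measurement.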

Compound 3, concentration lethal to 50% of the cells: > 10000 nM
Compound 3: no number, only a limit; the forecaster's own chance of this, stated with the estimate: 55%; at least 1.6-fold (0.22 log units) between middle value and limit.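

In this assay compound 3 gives > 10000 nM as a limit, not a number. Compound 1 also sits at a limit, so no step can be read between compound 1 and compound 3, and the record still holds no exact value: the limit of > 10000 nM in this assay, at which 3 of the 3 values shown sit.
The compounds shown leave open how far each lies from that limit, and whether carboxy or ethoxycarbonyl makes any difference in this test.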